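This account rests on a few compounds, and the source may have more. Where it says the series, first, only, none or still open, it means among the compounds named here.

Compound 3 `CC(O)c1cn(Cc2cc(=O)oc3cc(O)ccc23)nn1` is tested in a functional assay on HepG2 cells (Homo sapiens) for inhibition, read by MTT assay, with a stated time of 72 h (on this read-out lower numbers stand for stronger inhibition and higher numbers for weaker inhibition), where compound 3 gives > 100000 nM; this is a limit of the assay and not a number. Compound 1 `O=c1cc(Cn2cc(C3CC3)nn2)c2ccc(O)cc2o1` is also held at a limit in this assay, giving > 100000 nM. Compound 2 `O=c1cc(Cn2cc(CCO)nn2)c2ccc(O)cc2o1` likewise returns a limit in this assay, with > 100000 nM. Going by the values given here, because of the limit of > 100000 nM in this assay, at which 3 of the 3 values shown sit, none of the measured steps can be read: the step that the two limits leave unreadable from compound 1 to compound 2, the step that the two limits leave unreadable from compound 1 to compound 3 and the step that the two limits leave unreadable from compound 2 to compound 3 each run from one limit to another. Compound 3 therefore stands at the same limit as the two other measured compounds, with no number to set it apart from either. Compound 4 `O=c1cc(Cn2cc(-c3cc(F)cc(F)c3)nn2)c2ccc(O)cc2o1` has not yet been measured. It differs from compound 3 by 3,5-difluorophenyl in place of 1-hydroxyethyl on an aromatic carbon, the 3,5-difluorophenyl sitting next to the ring nitrogen, two ring bonds from the ring atom that bears a large group. Among the compounds with values here, no measured step bears on this change with a readable size, so the data give no direction for it beyond the scatter. The estimate for compound 4 in this assay is 80000 nM, with a range from 20000 nM to 300000 nM. The expected step of an at least 1.2-fold lower number from compound 3 to compound 4 (0.09 log units; that floor lies within the scatter) is an estimate, not a measurement.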

Compound 4, half-maximal inhibitory concentration: 38900 nM
Compound 4: middle estimate off by 2.1-fold (0.31 log units), on the high side; measured number inside the range.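

In this assay compound 4 gives 38900 nM, the first number rather than a limit for a group on this aromatic carbon of the five-membered ring, and so the first sign that this position can change the read-out. The change to 3,5-difluorophenyl gives an at least 2.5-fold lower number from compound 3 to compound 4 (0.41 log units; beyond the scatter) in place of 1-hydroxyethyl, an at least 2.5-fold lower number from compound 2 to compound 4 (0.41 log units; beyond the scatter) in place of 2-hydroxyethyl and an at least 2.5-fold lower number from compound 1 to compound 4 (0.41 log units; beyond the scatter) in place of cyclopropyl, so the step appears against each of the three groups, including the one that carries a ring of its own. The steps among the three earlier compounds cannot be read, and each of these new steps gives only a floor, since one end of each rests on a limit: the limit of > 100000 nM in this assay, at which 3 of the 4 values shown sit.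

Going by these compounds, the true size of these steps remains open, as does how far the read-out can move at this position. The compounds shown also do not separate the part played by the six-membered aromatic ring from that of its two fluorine atoms, a question that a plain phenyl or a 3,5-dichlorophenyl group would address.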